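Compound 3 to compound 4: chloro out, diethylamino in

The compounds below may be only part of what the source reports. "The series", "measured", "known", "first", "only" and "open" are said of these compounds alone.

Three members of the series are in hand on a shared core: compound 1 (`CC(=O)OC/C1=C/C[C@](C)(CCC=C(C)C)/C=C/[C@@H](OC(=O)C=C(C)C)[C@](C)(O)/C=C/C1=O`), compound 2 (`COC/C1=C/C[C@](C)(CCC=C(C)C)/C=C/[C@@H](OC(=O)C=C(C)C)[C@](C)(O)/C=C/C1=O`) and compound 3 (`CC(C)=CCC[C@]1(C)/C=C/[C@@H](OC(=O)C=C(C)C)[C@](C)(O)/C=C/C(=O)/C(CCl)=C\C1`). In a functional assay on A549 cells (Homo sapiens) for antiproliferative activity, read by MTT assay, with a stated time of 48 h (on this read-out higher numbers stand for weaker inhibition and lower numbers for stronger inhibition), compound 1 gives (2950 nM) and compound 2 gives (3950 nM), a pair separated by a step within the scatter (a 1.3-fold higher number from compound 1 to compound 2 (0.13 log units; within the scatter)). Compound 3 gives (150 nM), the lowest of the three numbers, and both steps to it are large: (a 20-fold lower number from compound 1 to compound 3 (1.29 log units; beyond the scatter)) and (a 26-fold lower number from compound 2 to compound 3 (1.42 log units; beyond the scatter)).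

Compound 4 (`CCN(CC)C/C1=C/C[C@](C)(CCC=C(C)C)/C=C/[C@@H](OC(=O)C=C(C)C)[C@](C)(O)/C=C/C1=O`) remains unmeasured. The change (diethylamino in place of chloro on a saturated chain carbon bound to a double-bonded ring carbon) puts diethylamino in place of chloro on a saturated chain carbon bound to a double-bonded ring carbon. No amine has been measured in the series, so the size of this step rests on weak ground. Within the data shown here, the only guide is that acetoxy in compound 1 (2950 nM) and methoxy in compound 2 (3950 nM) both stand well above chloro, so a large step toward higher numbers is expected (a 10-fold higher number from compound 3 to compound 4 (1.00 log units; beyond the scatter)). For compound 4 the estimated value is (1500 nM), with an expected range from (300 nM) to (6000 nM).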

Compound 4, half-maximal inhibitory concentration: 130 nM
Beside the measured number, compound 4's estimate is 12-fold (1.06 log units) above it, outside the stated range (below it).
By their numbers in this assay, from the lowest: compounds 4 and 3 (each within the scatter of the next); then compounds 1 and 2 (each within the scatter of the next).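

Working notes: in (this assay), the step (a 1.2-fold lower number from compound 3 to compound 4 (0.06 log units; within the scatter)) shows that on a saturated chain carbon bound to a double-bonded ring carbon, chloro is not the only group that gives a low number. Diethylamino, with its 5 heavy atoms against 1 for chloro, also stands well apart from the two oxygen-linked groups, as the steps (a 30-fold lower number from compound 2 to compound 4 (1.48 log units; beyond the scatter)) and (a 23-fold lower number from compound 1 to compound 4 (1.36 log units; beyond the scatter)) show, so at this position a low number does not depend on a halogen. No supporting data bear on why chloro and diethylamino read alike here.

On these data alone, it remains open whether other amines, such as dimethylamino or a longer-chain dialkylamino group, keep these low numbers. As far as these compounds go, whether bromo behaves like chloro at this position is equally open.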